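From benzamido to pyrrolidin-1-yl on a shared core

The compounds below may be only part of what the source reports. "The series", "measured", "known", "first", "only" and "open" are said of these compounds alone.

Compound 1 `O=C(Nc1ccc(O)c2c(=O)cc(-c3ccccc3Cl)oc12)c1ccccc1`: 13000 nM
Compound 2 `O=C(Nc1ccc(O)c2c(=O)cc(-c3ccccc3Cl)oc12)c1ccc(Cl)cc1`: 5500 nM
Compound 3 `COc1ccc(C(=O)Nc2ccc(O)c3c(=O)cc(-c4ccccc4Cl)oc23)cc1`: 5000 nM

In a functional assay on ID8 cells (Mus musculus) for antiproliferative activity (a higher number here means a weaker inhibitor, a lower number a stronger inhibitor), compound 1 has the highest number of the three and is the weakest inhibitor measured so far. Chloro in place of hydrogen on an aromatic carbon gives a 2.4-fold lower number from compound 1 to compound 2 (0.37 log units; beyond the scatter) and methoxy in place of hydrogen gives a 2.6-fold lower number from compound 1 to compound 3 (0.41 log units; beyond the scatter) as its two modest steps. Between the two substituted compounds the step is a 1.1-fold lower number from compound 2 to compound 3 (0.04 log units; within the scatter) and stays within the scatter.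

Compound 4 `O=c1cc(-c2ccccc2Cl)oc2c(N3CCCC3)ccc(O)c12` carries pyrrolidin-1-yl in place of benzamido on an aromatic carbon, para to a hydroxy group, and the change is counted as pyrrolidin-1-yl in place of benzamido on an aromatic carbon in full. The measured steps bear on this only loosely. Among the compounds with values here, all three alter a substituent on the ring of the benzamido group, whereas here the whole group leaves, and no measured compound lacks it. They show only modest movement, and they give no direction for this larger change. The expected step is therefore a 1.3-fold lower number from compound 1 to compound 4 (0.11 log units; within the scatter) with no firm shift beyond the scatter anticipated. For compound 4 the estimated value is 10000 nM with an expected range from 3000 nM to 35000 nM in this wide estimate.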

Compound 4, half-maximal inhibitory concentration: 9300 nM
Beside the measured number, compound 4's estimate is 1.1-fold (0.03 log units) above it; the measured number falls inside the stated range.
By their numbers in this assay, from the lowest: compounds 3, 2, 4 and 1 (each within the scatter of the next, the first and the last beyond it).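

In this assay, pyrrolidin-1-yl in place of benzamido on this aromatic carbon, para to a hydroxy group, gives a 1.4-fold lower number from compound 1 to compound 4 (0.15 log units; within the scatter) and so leaves the number within the scatter. The earlier steps shown here only changed a substituent on the ring of the benzamido group, so they could not show what this result shows: the whole group, with its six-membered aromatic ring, its carbonyl and the amide hydrogen, can give way to a smaller five-membered non-aromatic ring without a change beyond the scatter in this assay. Nothing measured here accounts for this result or says what either group does in the cells.

The compounds shown leave open how a morpholin-4-yl group, an open-chain amine or a carboxylic acid would behave at this place on the shared core. They also leave open whether chloro or methoxy on the pyrrolidin-1-yl ring would bring any step like those seen on the ring of the benzamido group.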